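Replacing the Carbamoyl Group of Compound 1

The compounds below may be only part of what the source reports. "The series", "measured", "known", "first", "only" and "open" are said of these compounds alone.

- Compound 1 `Cc1cc2c(C(=O)NCC#N)cccc2n1-c1nc2c(c(NCc3ccccc3)n1)CCCC2` measured at 468 nM
- Compound 2 `Cc1cc2c(C(=O)NCCC#N)cccc2n1-c1nc2c(c(NCc3ccccc3)n1)CCCC2` measured at 517 nM
- Compound 3 `CC#CCNC(=O)c1cccc2c1cc(C)n2-c1nc2c(c(NCc3ccccc3)n1)COCC2` measured at 524 nM

In a functional assay on MIA PaCa-2 cells (Homo sapiens) for antiproliferative activity (a lower number here means that less compound is needed, a higher number that more compound is needed for the effect), compound 1 gives 468 nM as its half-maximal effective concentration. The numbers for the other two compounds lie within the usual scatter of it, so compound 1 stands level with both.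

Compound 4 `C#CC(=O)Nc1cccc2c1cc(C)n2-c1nc2c(c(NCc3ccccc3)n1)CCCC2` carries (ethynylcarbonyl)amino in place of (cyanomethyl)carbamoyl on an aromatic carbon. Within the data shown here, only one measured step touches this group: a 1.1-fold higher number from compound 1 to compound 2 (0.04 log units; within the scatter) is small and stays within the scatter. That step alters just the chain on the amide-type nitrogen, whereas compound 4 replaces the whole group. Among the measured compounds shown here, compound 3 also differs in the core, so it offers no clean step of one change. For the measured compounds named here, no measured compound carries the (ethynylcarbonyl)amino group, so the data point in no direction for this change.

The expected step is a 1.2-fold higher number from compound 1 to compound 4 (0.07 log units; within the scatter) in this assay and this estimate has no firm direction behind it. For compound 4 the estimated value is 550 nM with an expected range from 150 nM to 2500 nM as its wide margin.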

Compound 4, half-maximal effective concentration: 131 nM
Estimate against measurement, compound 4: 4.2-fold (0.62 log units) above; measured number below the stated range.
By their numbers in this assay, from the lowest: compound 4; then compounds 1, 2 and 3 (each within the scatter of the next).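

In this assay the group on this aromatic carbon of a six-membered aromatic ring of carbon only clearly matters: the step of a 3.6-fold lower number from compound 1 to compound 4 (0.55 log units; beyond the scatter) and the step of a 3.9-fold lower number from compound 2 to compound 4 (0.60 log units; beyond the scatter) both lie beyond the scatter, whereas the step of a 1.1-fold higher number from compound 1 to compound 2 (0.04 log units; within the scatter), which only alters the chain on the amide-type nitrogen, does not. The swap changes several things at once: the nitrile leaves, the group is now joined to the ring through its nitrogen and not through its carbonyl carbon, and it has one heavy atom and one hydrogen-bond acceptor fewer, so this single change cannot show which of these differences goes with the lower number. Nothing measured here explains why the number falls.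

The compounds shown leave open whether the triple bond of the (ethynylcarbonyl)amino group takes part at all, a question that an acetylamino or propanoylamino group at the same place would address. They also leave open whether the (ethynylcarbonyl)amino group would give a similar step on the core of compound 3.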